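This account rests on a few compounds, and the source may have more. Where it says the series, first, only, none or still open, it means among the compounds named here.

In a functional assay on K562 cells (Homo sapiens), read by MTT assay, with a stated time of 72 h (on this read-out higher numbers stand for weaker inhibition and lower numbers for stronger inhibition), compound 1 `COc1ncnc2c1c(-c1ccoc1)cn2[C@@H]1O[C@H](CO)[C@@H](O)[C@H]1O` gives 2820 nM, the lower of the two numbers in this set. Compound 2 `CN(C)c1ncnc2c1c(-c1ccoc1)cn2[C@@H]1O[C@H](CO)[C@@H](O)[C@H]1O` gives 14900 nM, and the step of a 5.3-fold higher number from compound 1 to compound 2 (0.72 log units; beyond the scatter) lies beyond the scatter. Compound 3 `Cc1ncnc2c1c(-c1ccoc1)cn2[C@@H]1O[C@H](CO)[C@@H](O)[C@H]1O` reaches only the limit of the assay, > 20000 nM. The step of an at least 7.0-fold higher number from compound 1 to compound 3 (0.85 log units; beyond the scatter) and the step of an at least 1.3-fold higher number from compound 2 to compound 3 (0.12 log units; that floor lies within the scatter) both rest on that limit (the limit of > 20000 nM in this assay, at which 1 of the 3 values shown sits). Compound 4 `COc1ncnc2c1c(-c1ccccc1)cn2[C@@H]1O[C@H](CO)[C@@H](O)[C@H]1O` has not been measured. It differs from compound 1 by phenyl in place of furan-3-yl on an aromatic carbon. Among the compounds with values here, every measured step exchanges the methoxy group on an aromatic carbon while the furan-3-yl stays in place, so none of them bears on the exchange of the furan-3-yl for phenyl, and the comparison between compound 1 and compound 4 has no precedent within this set. Compound 1 is therefore the only anchor, and the step of a 1.2-fold higher number from compound 1 to compound 4 (0.09 log units; within the scatter) is expected to stay small, with no confident direction and a wide margin on either side. Compound 4 is estimated at 3500 nM, within a range from 900 nM to 14000 nM.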

Compound 4, half-maximal inhibitory concentration: > 20000 nM
Compound 4 was reported as a limit (the forecaster's own chance of this, stated with the estimate: 12%); middle value at least 5.7-fold (0.75 log units) away from the limit.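

Within the data shown here, at this place, on an aromatic carbon of a five-membered aromatic ring with 1 nitrogen, phenyl in place of furan-3-yl gives an at least 7.0-fold higher number from compound 1 to compound 4 (0.85 log units; beyond the scatter) in this assay, so the read-out responds to this group as well as to the methoxy group exchanged in the earlier compounds. In the same assay, compound 4 gives > 20000 nM, which is a limit and not a number, so only the floor of this step can be read. Compound 4 thus sits at the same limit as compound 3: the limit of > 20000 nM in this assay, at which 2 of the 4 values shown sit.

Leaving furan-3-yl changes the ring size and removes a hydrogen-bond acceptor together, so the compounds shown cannot separate the two. They also leave open how a thiophen-3-yl or pyridin-3-yl group would read at this place with the methoxy group kept.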